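Ansamycin macrolactam series: removing the aromatic methoxy

This account rests on a few compounds, and the source may have more. Where it says the series, first, only, none or still open, it means among the compounds named here.

Compound 2 `COc1c(O)cc2cc1C[C@@H](C)C[C@H](OC)[C@H](O)[C@@H](C)/C=C(\C)[C@H](OC(N)=O)[C@@H](OC)CC/C=C(\C)C(=O)N2` stands lowest of the two numbers measured in a functional assay on K562 cells (Homo sapiens) for activation (on this read-out higher numbers stand for an effect only at larger amounts of compound and lower numbers for an effect already at smaller amounts), where compound 2 gives 760 nM; compound 1 `CO[C@H]1C[C@H](C)Cc2cc(cc(O)c2O)NC(=O)/C(C)=C/CC[C@H](OC)[C@@H](OC(N)=O)/C(C)=C/[C@H](C)[C@H]1O` gives 21000 nM. Compound 3 `CO[C@H]1C[C@H](C)Cc2cc(O)cc(c2)NC(=O)/C(C)=C/CC[C@H](OC)[C@@H](OC(N)=O)/C(C)=C/[C@H](C)[C@H]1O` differs from compound 2 by hydrogen in place of methoxy on an aromatic carbon. Among the compounds with values here, the only measured step at this position, a 28-fold lower number from compound 1 to compound 2 (1.44 log units; beyond the scatter), is large, which shows the position matters, but it does not show the effect of removing the methoxy outright. A moderate rise in the number, beyond the scatter, is therefore expected, namely a 3.3-fold higher number from compound 2 to compound 3 (0.52 log units; beyond the scatter). Compound 3 is estimated at 2500 nM, within 500 nM to 12000 nM.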

Compound 3, half-maximal effective concentration: 1900 nM
Estimate against measurement, compound 3: 1.3-fold (0.12 log units) above; the range from low to high includes it.
By their numbers in this assay, from the lowest: compound 2; then compound 3; then compound 1.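

Removing the methoxy outright gives a 2.5-fold higher number from compound 2 to compound 3 (0.40 log units; beyond the scatter) in this assay, a modest step, while hydrogen in place of hydroxy gives an 11-fold lower number from compound 1 to compound 3 (1.04 log units; beyond the scatter) and so a large one. At this aromatic carbon the numbers thus rise from methoxy through hydrogen to hydroxy, with every step beyond the scatter. The hydroxy therefore stands out more than the loss of the methoxy does.

As far as these compounds go, whether an ethoxy, an amine or a fluorine would follow this order stays open. Nothing available explains the order of these three groups.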